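Acetylation of a hydroxy group on a sesquiterpene lactone core

This account rests on a few compounds, and the source may have more. Where it says the series, first, only, none or still open, it means among the compounds named here.

Compound 1 `C=C1C(=O)O[C@]2(C)CC[C@@H]1C[C@H](O)[C@@]1(C)CC[C@H](OC(C)=O)[C@@](C)(CCC2=O)O1` was tested in a functional assay on HEp-2 cells (Homo sapiens) for cytotoxicity; on this read-out higher numbers stand for weaker inhibition and lower numbers for stronger inhibition. Compound 1 gives > 20 ug/mL, a limit of the assay rather than a number. Compound 2 `C=C1C(=O)O[C@]2(C)CC[C@@H]1C[C@H](O)[C@@]1(C)CC[C@H](O1)[C@](C)(O)CC[C@H]2OC(C)=O` shares the same core with a rearranged ring. In this assay compound 2 gives > 20 ug/mL, again only a limit. Both values therefore sit at the limit of > 20 ug/mL in this assay, at which 2 of the 2 values shown sit. Compound 3 `C=C1C(=O)O[C@]2(C)CC[C@@H]1C[C@H](OC(C)=O)[C@@]1(C)CC[C@H](O1)[C@](C)(O)CC[C@H]2OC(C)=O` differs from compound 2 by acetyl in place of hydrogen on an oxygen on a saturated carbon. Among the measured compounds shown here, no measured pair here shows what this change does, so no step beyond the scatter is expected in this assay: the estimated shift a step that the limit leaves unreadable from compound 2 to compound 3 is small. Compound 3 is expected to give 25 ug/mL, between 12 ug/mL and 60 ug/mL.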

Compound 3, half-maximal inhibitory concentration: > 20 ug/mL
Compound 3: no number, only a limit (the forecaster's own chance of this, stated with the estimate: 80%); the middle value does not contradict the limit.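

No step from compound 2 to compound 3 can be read in this assay, because both of their values are limits of the assay: the limit of > 20 ug/mL in this assay, at which 3 of the 3 values shown sit.

The compounds shown leave open what the change from hydroxy to acetoxy does to cytotoxicity.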